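The source may hold more compounds than are shown below. What is called first, only, known or untested is meant among the compounds shown, and "the series" means these compounds.

Measured compounds in an ADME assay on Vero cells (Chlorocebus sabaeus) for cytotoxicity, read by CellTiter-Glo, with a stated time of 72 h; on this read-out lower numbers stand for higher toxicity in this test and higher numbers for lower toxicity in this test:
- Compound 1, `CCOC(=O)Nc1cc(NC(C)CCCN(CC)CC)c2nc(-c3cccs3)c(-c3cccs3)nc2n1`: compound 1 gives > 40000 nM, a limit of the assay and not a number.
- Compound 2, `CCOC(=O)Nc1cc(NCCCCN(CC)CC)c2nc(-c3cccs3)c(-c3cccs3)nc2n1`: compound 2 gives > 40000 nM, likewise a limit of the assay.
- Compound 3, `CCOC(=O)Nc1cc(NCCN(CC)CC)c2nc(-c3cccs3)c(-c3cccs3)nc2n1`: compound 3 gives 6300 nM.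

Among the measured compounds shown here, compound 3 thus holds the only number in this assay; the other two values sit at the limit of > 40000 nM in this assay, at which 2 of the 3 values shown sit. The steps leading to it are an at least 6.3-fold lower number from compound 1 to compound 3 (0.80 log units; beyond the scatter) and an at least 6.3-fold lower number from compound 2 to compound 3 (0.80 log units; beyond the scatter), while a step that the two limits leave unreadable from compound 1 to compound 2 cannot be read. Both readable steps concern the length of the chain between the two nitrogens, not the substituents on the terminal nitrogen.

Compound 4, `CCOC(=O)Nc1cc(NCCN(C)C)c2nc(-c3cccs3)c(-c3cccs3)nc2n1`, differs from compound 3 only as dimethylamino in place of diethylamino on a saturated chain carbon, two bonds along the chain from a nitrogen on an aromatic ring. For the measured compounds named here, no measured pair in this set varies the alkyl groups on that terminal nitrogen, so no step bears directly on this change, and the expectation is a step of a 1.3-fold higher number from compound 3 to compound 4 (0.10 log units; within the scatter), within the scatter. Compound 4 is therefore expected to give about 8000 nM in this assay, in a range of 3000 nM to 25000 nM.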

Compound 4, half-maximal cytotoxic concentration: 1600 nM
The estimate for compound 4 lay 5.0-fold (0.70 log units) above the measured number; measured number below the stated range.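

In this assay, compound 4 shows that the groups on the terminal nitrogen matter as well as the length of the chain: with the 2-carbon-free comparison of the chain held as in compound 3, dimethylamino in place of diethylamino gives a 3.9-fold lower number from compound 3 to compound 4 (0.60 log units; beyond the scatter), towards higher toxicity in this test. Set against the two longer chains, the same compound gives an at least 25-fold lower number from compound 2 to compound 4 (1.39 log units; beyond the scatter) and an at least 25-fold lower number from compound 1 to compound 4 (1.39 log units; beyond the scatter). Compound 1 and compound 2 each stand at a limit of the assay and not at a number: the limit of > 40000 nM in this assay, at which 2 of the 4 values shown sit.

Going by these compounds, it stays open how other groups on that nitrogen, such as a primary amine, pyrrolidine or morpholine, would read in this assay. On these data alone, it also stays open whether dimethylamino on the longer chains of compound 1 and compound 2 would lower the number in the same way.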